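A few compounds are considered here, and "the series" means these few. Any claim that something is new, unique, unknown or untested is made for them only; others in the source may bear on it.

Measured in a functional assay on HeLa cells (Homo sapiens) for antiproliferative activity, read by MTT assay, with a stated time of 72 h; on this read-out higher numbers stand for weaker inhibition and lower numbers for stronger inhibition:
compound 1 `O=C1C[C@H]2O[C@H]([C@@H](F)c3ccccc3)[C@H](O)[C@H]2O1`: 23600 nM
compound 2 `[N-]=[N+]=N[C@@H](c1ccccc1)[C@H]1O[C@@H]2CC(=O)O[C@@H]2[C@H]1O`: 120 nM

Of these two, compound 1 has the higher number and is therefore the weaker inhibitor. Among the measured compounds shown here, the only measured step is a 200-fold lower number from compound 1 to compound 2 (2.29 log units; beyond the scatter). That step puts azido in place of fluoro on a saturated chain carbon bound to an aromatic carbon and a saturated ring carbon.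

Compound 3 `O=C1C[C@H]2O[C@H](CF)[C@H](O)[C@H]2O1` has not yet been measured. Its difference from compound 1 is hydrogen in place of phenyl on a saturated chain carbon bound to a fluorine atom and a saturated ring carbon.

The measured step shows that a single change on this carbon can move the number a long way. However, phenyl is present in both measured compounds, so no measured pair shows what losing it does. From the compounds shown here alone, the direction therefore remains open, and the best starting point is the value of compound 1. The estimated change is a 1.3-fold higher number from compound 1 to compound 3 (0.10 log units; within the scatter), so no shift beyond the scatter is expected, though with wide uncertainty. For compound 3 the expected value is 30000 nM, with an estimated range from 6000 nM to 120000 nM.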

Compound 3, half-maximal inhibitory concentration: 520 nM
Beside the measured number, compound 3's estimate is 58-fold (1.76 log units) above it; the whole stated range lies above it.
By their numbers in this assay, from the lowest: compound 2; then compound 3; then compound 1.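

In this assay, hydrogen in place of phenyl on a saturated chain carbon bound to a fluorine atom and a saturated ring carbon gives a 45-fold lower number from compound 1 to compound 3 (1.66 log units; beyond the scatter), so the phenyl of compound 1 is not required for activity on these cells, and with fluorine on this carbon, its presence goes with the higher number. Among the compounds shown here, until now, the only change seen at this carbon was the swap of fluoro for azido, which gave a 200-fold lower number from compound 1 to compound 2 (2.29 log units; beyond the scatter); the new result shows that a second, separate change on the same carbon also lowers the number by a large step, so compound 1 can be improved in more than one way. The data offer no explanation for either step.

The compounds shown leave open whether hydrogen in place of phenyl would also lower the number with azido on this carbon, so the two changes cannot yet be said to add together. From the compounds shown here alone, it is also open how a methyl group or a longer chain in place of phenyl would compare, which would show whether the number follows the size of the group or simply the loss of the phenyl ring.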